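This account rests on a few compounds, and the source may have more. Where it says the series, first, only, none or still open, it means among the compounds named here.

Compound 1 `O=C(O)c1cccc(C2=C(c3cc(Br)ccc3OCc3ccccc3)CCC2)c1`: 12.6 nM
Compound 2 `O=C(O)c1cccc(C2=C(c3cc(Br)ccc3OCc3ccc(F)cc3F)CCC2)c1`: 5.01 nM
Compound 3 `CSc1ccc(OCc2ccc(F)cc2F)c(C2=C(c3cccc(C(=O)O)c3)CCC2)c1`: 15.9 nM

All three were tested in an assay on isolated protein for inhibition of prostaglandin E2 receptor EP1 subtype (Homo sapiens); a lower number here means a stronger inhibitor, a higher number a weaker inhibitor. Among these numbers compound 2 stands lowest: compound 1 is nearest, separated by a 2.5-fold lower number from compound 1 to compound 2 (0.40 log units; beyond the scatter), and compound 3 is furthest, separated by a 3.2-fold higher number from compound 2 to compound 3 (0.50 log units; beyond the scatter). Compound 4 `O=C(O)c1cccc(C2=C(c3cc(Br)ccc3OCc3ccc(Cl)cc3)CCC2)c1` has not yet been measured. It differs from compound 2 in one place: 4-chlorophenyl in place of 2,4-difluorophenyl on a saturated chain carbon bound to an oxygen on an aromatic ring.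

Of the two measured steps, only one touches the same place. Going from compound 1 to compound 2 replaced a plain phenyl with a 2,4-difluorophenyl on that saturated chain carbon and gave a 2.5-fold lower number from compound 1 to compound 2 (0.40 log units; beyond the scatter), a modest lowering. The other step, a 3.2-fold higher number from compound 2 to compound 3 (0.50 log units; beyond the scatter), swapped methylsulfanyl for bromo elsewhere on the shared core and says little about the present change. Compound 4 keeps a halogen-bearing ring at that position, with one chlorine in place of two fluorines, so it is expected to sit between compound 1 and compound 2 or close to compound 2, with a step of a 1.6-fold higher number from compound 2 to compound 4 (0.20 log units; within the scatter) that is expected to stay within the scatter. For compound 4 the estimate is 8 nM, expected to fall between 3.2 nM and 20 nM.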

Compound 4, half-maximal inhibitory concentration: 12.6 nM
Estimate against measurement, compound 4: 1.6-fold (0.20 log units) below; the range from low to high includes it.
By their numbers in this assay, from the lowest: compound 2; then compounds 1, 4 and 3 (each within the scatter of the next).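

At this saturated chain carbon bound to an oxygen on an aromatic ring, carrying a halogen on the ring is not enough to hold the lower number: in this assay putting 4-chlorophenyl in place of 2,4-difluorophenyl gives a 2.5-fold higher number from compound 2 to compound 4 (0.40 log units; beyond the scatter) and takes back the whole of the earlier gain. Seen from the other side, chloro in place of hydrogen on that ring shows no change at the digits printed from compound 1 to compound 4 (within the scatter) in this assay and so adds nothing that this measurement can detect. Among these compounds, the lowering seen as a 2.5-fold lower number from compound 1 to compound 2 (0.40 log units; beyond the scatter) therefore goes with the 2,4-difluorophenyl group specifically, and compound 4 stands against any broader rule that a halogen on this ring lowers the number.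

On these data alone, it remains open whether a 4-fluorophenyl or a 2,4-dichlorophenyl group would behave like the 2,4-difluorophenyl group or like the 4-chlorophenyl group, which would show whether the element or the number of halogens matters more here. Nothing measured alongside these numbers explains why the two halogen-bearing groups differ.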